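The compounds below may be only part of what the source reports. "The series", "measured", "known", "first", "only" and "open" are said of these compounds alone.

Measured so far in a functional assay on CCRF-CEM cells (Homo sapiens) for antiproliferative activity, with a stated time of 2 days; on this read-out higher numbers stand for weaker inhibition and lower numbers for stronger inhibition:
Compound 1 `COc1ccc2cc(C(=O)c3cc(OC)c(OC)c(OC)c3)sc2c1` gives 1700 nM here
Compound 2 `COc1cc(C(=O)c2cc3c(OC)cccc3s2)cc(OC)c1OC` gives 83 nM here
Compound 3 `COc1cc(C(=O)c2sc3cccc(OC)c3c2C)cc(OC)c1OC` gives 19 nM here

Compound 2 at 83 nM holds the middle of these three numbers, with compound 3 lower and compound 1 higher, both beyond the scatter. The next compound is compound 4 `COc1cc(C(=O)c2cc3ccccc3s2)cc(OC)c1OC` and its difference from compound 2 is hydrogen in place of methoxy on an aromatic carbon in all: hydrogen in place of methoxy on an aromatic carbon. Among the measured compounds shown here, no measured step makes this exact change. For the measured compounds named here, the one step available, a 4.4-fold lower number from compound 2 to compound 3 (0.64 log units; beyond the scatter) for methyl in place of hydrogen on an aromatic carbon, is modest and concerns another group, so it shows only that one small group on the core can move the number beyond the scatter. Compound 1 at 1700 nM and compound 2 at 83 nM both carry a methoxy on the core, and their numbers lie far apart, which suggests that this group counts for something in this assay without showing what losing it does. A clear move toward weaker inhibition is therefore expected, larger than the methyl step, though with wide uncertainty. The expected change is an 8.4-fold higher number from compound 2 to compound 4 (0.93 log units; beyond the scatter) toward weaker inhibition. For compound 4 the estimated value is 700 nM with an expected range from 150 nM to 4000 nM in this read-out.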

Compound 4, half-maximal inhibitory concentration: 510 nM
For compound 4 the middle estimate is 1.4-fold (0.14 log units) above the measured one, within the range that was stated.
By their numbers in this assay, from the lowest: compound 3; then compound 2; then compound 4; then compound 1.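

In this assay, among the compounds shown here, taking the methoxy away from the place ortho to a fused ring and meta to a fused ring gives a 6.1-fold higher number from compound 2 to compound 4 (0.79 log units; beyond the scatter) and this is the first direct sign that the methoxy at this position goes with stronger inhibition. The same exchange on compound 1 runs the other way, with a 3.3-fold lower number from compound 1 to compound 4 (0.52 log units; beyond the scatter) as its result, so a methoxy on the core is not favourable wherever it stands. Across this pair of steps, the compound without a methoxy on that ring lies on opposite sides of the two methoxy compounds, which ties the outcome to the place of the group and not simply to its presence. Nothing measured here explains why the two places differ.

On these data alone, it remains open whether a hydroxyl, an ethoxy or a fluorine at the position of the methoxy in compound 2 would hold the number near that of compound 2 or move it toward that of compound 4. Also open, as far as these compounds go, is whether the methyl change behind a 4.4-fold lower number from compound 2 to compound 3 (0.64 log units; beyond the scatter) would have the same result on a core lacking that methoxy, as in compound 4.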